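The source may report more compounds than this note shows. Statements on the series, on what has been measured and on what is new or still open speak of the compounds shown alone.

Compound 1 `CS(=O)(=O)Oc1c(C(=O)NCc2ccc(F)cc2)nc(Br)c2cccnc12` gives "not determined" (no result reported) in a functional assay on MCF7 cells (Homo sapiens) for cytotoxicity, read by MTT assay, with a stated time of 72 h (on this read-out lower numbers stand for stronger inhibition and higher numbers for weaker inhibition), so its standing on this read-out is open. Compound 2 `N[C@H]1CC[C@H](Nc2c(C(=O)NCc3ccco3)nc(Br)c3cccnc23)CC1` likewise gives "not determined" (no result reported) in this assay. Compound 3 `NCCCNc1c(C(=O)NCc2ccc(F)cc2)ncc2cccnc12` reaches only the limit of this assay: compound 3 gives > 10000 nM, a limit rather than a number, at the limit of > 10000 nM in this assay, at which 1 of the 3 values shown sits. Compound 4 `NCCNc1c(C(=O)NCc2ccc(F)cc2)nc(Br)c2cccnc12` differs from compound 1 by (2-aminoethyl)amino in place of (methylsulfonyl)oxy on an aromatic carbon. No measured step joins compound 1 and compound 4, so the size of this move in this assay cannot be read from the numbers shown. Because compound 3 stands at > 10000 nM, a limit, no step beyond the scatter is expected in either direction. Compound 4 is expected to give about 8000 nM in this assay, within 2000 nM to 30000 nM, with a fair chance that only a limit is returned.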

Compound 4, half-maximal inhibitory concentration: 6000 nM
For compound 4 the middle estimate is 1.3-fold (0.12 log units) above the measured one, and the stated range covers the measured number.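

No new step can be read in this assay between compound 4 and compound 1, compound 2 or compound 3. The compounds shown leave open how (2-aminoethyl)amino compares with (methylsulfonyl)oxy on the core of compound 1.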